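Methoxy for Chloro on a Nitrate-Free Amide Core

The compounds below may be only part of what the source reports. "The series", "measured", "known", "first", "only" and "open" are said of these compounds alone.

Of the compounds shown here, three have been tested so far in a functional assay on the whole organism (strain albino) for inhibition, with Rattus norvegicus as the target, read by paw edema, with stated times of 30 min and 1 h, at a dose of 100 mg/kg by the oral route; a lower number here means less inhibition, a higher number more inhibition at the dose given (going by the name of the read-out). Compound 1 `CC(O[N+](=O)[O-])C(=O)Nc1ccc(C(=O)/C=C/c2ccc(Cl)cc2)cc1` gives 45%, and compound 2 `COc1ccc(/C=C/C(=O)c2ccc(NC(=O)C(C)O[N+](=O)[O-])cc2)cc1` gives 43%. The two differ in one place, (methoxy in place of chloro on an aromatic carbon), and the step is a number 2 percentage points lower from compound 1 to compound 2 (within the scatter). Compound 3 `C/C(=N/O)c1ccc(OCC(=O)Nc2ccc(C(=O)/C=C/c3ccc(Cl)cc3)cc2)cc1` gives 39% in this assay; its values and those of compound 1 and compound 2 all sit within the scatter of one another. How the core of compound 3 differs from that of compound 1 is not broken down here.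

Compound 4 `COc1ccc(/C=C/C(=O)c2ccc(NC(=O)COc3ccc(/C(C)=N\O)cc3)cc2)cc1` has not yet been measured in this assay. It differs from compound 3 by methoxy in place of chloro on an aromatic carbon, which is the same change as that from compound 1 to compound 2, at the same kind of place.

Because that earlier step was a number 2 percentage points lower from compound 1 to compound 2 (within the scatter), the step from compound 3 to compound 4 is expected to be small as well, about a number 1 percentage points lower from compound 3 to compound 4 (within the scatter). Compound 4 is therefore estimated to give 38% in this assay, with a range expected from 28% to 48%.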

Compound 4, a percentage reported as inhibition, in the whole organism at one dose (the size of the read-out at that dose, not a potency): 33%
Estimate against measurement, compound 4: 5 percentage points above; the range from low to high includes it.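

Going from 4-chlorophenyl to 4-methoxyphenyl on the core of compound 3 gives, in this assay, a number 6 percentage points lower from compound 3 to compound 4 (within the scatter). Set beside the earlier step on the core of compound 1, the change reads alike on both cores: the same change on two cores in this assay, a number 2 percentage points lower (within the scatter) from compound 1 to compound 2 and a number 6 percentage points lower (within the scatter) from compound 3 to compound 4, 4 percentage points apart, within the scatter of two such steps. This shows that the change carries from one core to the other without a step that stands out from the scatter on either, but it does not show that methoxy truly lowers inhibition relative to chloro, and two pairs at a single oral dose cannot establish a rule for the whole series.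

The compounds shown leave open how other groups on this aromatic carbon, such as an amine or a carboxylic acid, would compare with chloro and methoxy. From the compounds shown here alone, it also remains open whether the two steps would still agree on a core other than these two, or at a dose other than the one used here.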